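Thioacylhydrazone amidines: swapping a fluoro- for a methylpyridyl

The source may hold more compounds than are shown below. What is called first, only, known or untested is meant among the compounds shown, and "the series" means these compounds.

Three amidine-thiosemicarbazides were tested in a functional assay on HeLa cells (Homo sapiens) for cytotoxicity, read by MTT assay, with a stated time of 72 h, tested at 100 uM; a lower number here means less inhibition of growth, a higher number more inhibition of growth at the concentration tested. Compound 1 `Cc1cccc(/C(N)=N/NC(=S)N2CCCCC2)n1` gives 85.4%, compound 2 `N/C(=N\NC(=S)N1CCOCC1)c1ccccn1` gives 87.2%, and compound 3 `N/C(=N\NC(=S)N1CCN(c2ccccn2)CC1)c1ccc(F)cn1` gives 83%. The number for compound 3 is the lowest of the three, yet compound 1 and compound 2 both lie within the usual scatter of it, so the three cannot be told apart. Compound 4 `Cc1ccnc(/C(N)=N/NC(=S)N2CCN(c3ccccn3)CC2)c1` differs from compound 3 in one place: 4-methylpyridin-2-yl in place of 5-fluoropyridin-2-yl on a carbon with a double bond to nitrogen. With no measured step between any two of these compounds, the change from compound 3 to compound 4 is expected to give a step of a number 1 percentage points higher from compound 3 to compound 4 (within the scatter) in this assay, which is none beyond the scatter. Compound 4 is therefore estimated at 84%, within a range from 72% to 94%.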

Compound 4, percent growth inhibition at one concentration: 85.6%
The estimate for compound 4 lay 1.6 percentage points below the measured number, and the stated range covers the measured number.
By their numbers in this assay, from the lowest: compounds 3, 1, 4 and 2 (each within the scatter of the next).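

In this assay, among the compounds shown here, the exchange of 5-fluoropyridin-2-yl for 4-methylpyridin-2-yl gives a number 2.6 percentage points higher from compound 3 to compound 4 (within the scatter) and provides the first direct comparison at this position. On a carbon with a double bond to nitrogen, these two pyridyl groups therefore cannot be told apart at the concentration tested. Nothing available explains this result.

The compounds shown leave open whether a phenyl ring or a carboxylic acid at this place would give a step beyond the scatter. They also leave open whether compound 3 and compound 4 would separate at lower concentrations.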